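The source may report more compounds than this note shows. Statements on the series, on what has been measured and on what is new or still open speak of the compounds shown alone.

Measured compounds in a functional assay on A549 cells (Homo sapiens) for cytotoxicity, read by sulforhodamine B assay; a lower number here means a stronger inhibitor, a higher number a weaker inhibitor:
compound 1 `C=C1[C@@H](OC(C)=O)C[C@@H]2[C@](C)(CO[Si](C)(C)C(C)(C)C)[C@H](OC(C)=O)CC[C@@]2(C)[C@@H]1C[C@@H](Nc1ccccc1)C1=CCOC1=O`: 4500 nM
compound 2 `C=C1[C@@H](OC(C)=O)C[C@@H]2[C@](C)(COC=O)[C@H](OC(C)=O)CC[C@@]2(C)[C@@H]1C[C@@H](Nc1ccc(Br)cc1)C1=CCOC1=O`: 15900 nM
compound 3 `C=C1[C@@H](OC(C)=O)C[C@@H]2[C@](C)(CO[Si](C)(C)C(C)(C)C)[C@H](OC(C)=O)CC[C@@]2(C)[C@@H]1C[C@@H](Nc1ccc(F)cc1)C1=CCOC1=O`: 4550 nM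

Compound 2 gives the highest number of the three, beyond the scatter from both compound 1 and compound 3. Compound 4 `C=C1[C@@H](OC(C)=O)C[C@@H]2[C@](C)(COC=O)[C@H](OC(C)=O)CC[C@@]2(C)[C@@H]1C[C@@H](Nc1ccccc1F)C1=CCOC1=O` is compound 2 with one change: 2-fluorophenyl in place of 4-bromophenyl on an amine nitrogen. Going by the values given here, the only measured step on the aromatic ring, a 1.0-fold higher number from compound 1 to compound 3 (0.00 log units; within the scatter), stayed within the scatter, but it swapped hydrogen for fluoro on a core that also carries a different group than compound 2; no measured pair trades bromo for fluoro or moves a halogen round the ring. The expected step is therefore small, a 1.4-fold lower number from compound 2 to compound 4 (0.16 log units; within the scatter), and compound 4 is estimated at 11000 nM, ranging from 3500 nM to 35000 nM in this assay.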

Compound 4, half-maximal inhibitory concentration: 23600 nM
Beside the measured number, compound 4's estimate is 2.1-fold (0.33 log units) below it, within the range that was stated.
By their numbers in this assay, from the lowest: compounds 1 and 3 (each within the scatter of the next); then compounds 2 and 4 (each within the scatter of the next).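

In this assay, 2-fluorophenyl in place of 4-bromophenyl on the amine nitrogen gave a 1.5-fold higher number from compound 2 to compound 4 (0.17 log units; within the scatter) and so stayed within the scatter, even though the halogen and its place on the ring both differ. Going by these compounds alone, this is the first measured step on the core of compound 2, and it shows that this exchange gives no change that can be told from the scatter. Nothing measured here offers a reason for this result.

The two differences within this exchange cannot be told apart from compound 2 and compound 4 alone. From the compounds shown here alone, whether a methoxy group or a carboxylic acid on the phenyl ring would move the number beyond the scatter remains open.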